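Cytotoxicity notes: the step from compound 2 to compound 3

A few compounds are considered here, and "the series" means these few. Any claim that something is new, unique, unknown or untested is made for them only; others in the source may bear on it.

In an ADME assay on HepG2 cells (Homo sapiens) for cytotoxicity, read by MTT assay, with a stated time of 7 days (on this read-out lower numbers stand for stronger inhibition and higher numbers for weaker inhibition), compound 2 (`O=C(c1cccnc1)N1N=C(c2ccc(O)cc2)CC1c1ccc(F)cc1`) gives 52400 nM and compound 1 (`CC(C)Oc1ccc(C2CC(c3ccc(O)cc3)=NN2C(=O)c2cccnc2)cc1`) gives 45400 nM, the two level within the scatter. Compound 3 (`CC(C)c1ccccc1C1CC(c2ccc(O)cc2)=NN1C(=O)c1cccnc1`) carries 2-isopropylphenyl in place of 4-fluorophenyl on a saturated ring carbon. For the measured compounds named here, the only measured step, a 1.2-fold higher number from compound 1 to compound 2 (0.06 log units; within the scatter), puts fluoro in place of isopropoxy on an aromatic carbon and stays within the scatter. Going by the values given here, no measured compound carries 2-isopropylphenyl, so this is weak guidance. The expected change in this assay is a 1.2-fold lower number from compound 2 to compound 3 (0.07 log units; within the scatter), nothing beyond the scatter. For compound 3 the estimate is 45000 nM, with an expected range of 22000 nM to 90000 nM.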

Compound 3, half-maximal inhibitory concentration: 49700 nM
The estimate for compound 3 lay 1.1-fold (0.04 log units) below the measured number; low and high end bracket the measured number.
By their numbers in this assay, from the lowest: compounds 1, 3 and 2 (each within the scatter of the next).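

On this saturated ring carbon, next to the ring nitrogen, only 4-fluorophenyl and 4-isopropoxyphenyl had been seen before. In this assay 2-isopropylphenyl gives a 1.1-fold lower number from compound 2 to compound 3 (0.02 log units; within the scatter) and also a 1.1-fold higher number from compound 1 to compound 3 (0.04 log units; within the scatter) so this group, with 9 heavy atoms against 7 for 4-fluorophenyl, stays within the scatter of both. No supporting data bear on why the numbers stay level.

All three compounds carry a carbon-only aromatic ring at this position. On these data alone, whether an amine or a carboxylic acid on that ring, or a plain alkyl chain in its place, would move the number beyond the scatter remains open.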